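Chloro to bromo on the sulfonyl aryl of compound 3

A few compounds are considered here, and "the series" means these few. Any claim that something is new, unique, unknown or untested is made for them only; others in the source may bear on it.

Compound 3 `CC1=NC(c2cn(S(=O)(=O)c3ccccc3Cl)c3ccc(C)cc23)CN1` gives the lowest of three numbers in an assay on isolated protein for inhibition of kallikrein-7 (Homo sapiens), read by fluorescence, with stated times of 10 min and 30 min (a higher number here means a weaker inhibitor, a lower number a stronger inhibitor), at 1200 nM. Its nearest neighbour is compound 1 `CC1=NC(c2cn(S(=O)(=O)c3ccc(Cl)cc3)c3ccc(C)cc23)CN1`, which gives 1900 nM; the step of a 1.6-fold lower number from compound 1 to compound 3 (0.20 log units; within the scatter) lies within the scatter. Compound 2 `CC1=NC(c2cn(S(=O)(=O)c3cccs3)c3ccc(C)cc23)CN1` stands furthest, at 11000 nM, and the step of a 9.2-fold lower number from compound 2 to compound 3 (0.96 log units; beyond the scatter) is modest. Compound 4 `CC1=NC(c2cn(S(=O)(=O)c3ccccc3Br)c3ccc(C)cc23)CN1` carries the change (bromo in place of chloro on an aromatic carbon), bromo in place of chloro on an aromatic carbon, ortho to a large group. Within the data shown here, no measured step swaps one halogen for another; the closest comparison, the move of chloro around the same ring, stayed within the scatter, while the larger step of a 5.8-fold higher number from compound 1 to compound 2 (0.76 log units; beyond the scatter) concerns the whole aryl group. The expected change is therefore a 1.1-fold lower number from compound 3 to compound 4 (0.04 log units; within the scatter), a step within the scatter. The estimate for compound 4 in this assay is 1100 nM, ranging from 500 nM to 2500 nM.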

Compound 4, half-maximal inhibitory concentration: 390 nM
Estimate against measurement, compound 4: 2.8-fold (0.45 log units) above, outside the stated range (below it).
By their numbers in this assay, from the lowest: compound 4; then compounds 3 and 1 (each within the scatter of the next); then compound 2.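

In this assay, the identity of the halogen at this position proved to matter, with a 3.1-fold lower number from compound 3 to compound 4 (0.49 log units; beyond the scatter) as a step beyond the scatter, whereas moving chloro around the ring had stayed within it. The 2-bromophenyl group also stands clear of the other sulfonyl groups, giving a 4.9-fold lower number from compound 1 to compound 4 (0.69 log units; beyond the scatter) and the large 28-fold lower number from compound 2 to compound 4 (1.45 log units; beyond the scatter) as its steps. Nothing available here bears on why bromo gives the lower number. As far as these compounds go, whether iodo or methyl in the same place would extend the gain remains open, as does whether 4-bromophenyl would keep it.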